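Two Flat Responses and an Azole Exchange

The compounds below may be only part of what the source reports. "The series", "measured", "known", "first", "only" and "open" are said of these compounds alone.

compound 1 `Cc1nc(-c2ccccc2NCC2=NCCN2)n(C)n1`: 0%
compound 2 `Cc1n[nH]c(-c2ccccc2NCC2=NCCN2)n1`: 0%

In a functional assay with Alpha-1B adrenergic receptor (Homo sapiens) as the target, read by calcium flux (on this read-out lower numbers stand for smaller maximal responses and higher numbers for larger maximal responses), compound 1 gives 0%, and compound 2 gives 0%. Within the data shown here, the one step between them, no change at the digits printed from compound 1 to compound 2 (within the scatter), came from hydrogen in place of methyl on an aromatic nitrogen and left the maximal response where it was. Compound 2 therefore stands level with compound 1, both at the floor of this read-out.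

Compound 3 `Cn1ccnc1-c1ccccc1NCC1=NCCN1` differs from compound 2 by 1-methyl-1H-imidazol-2-yl in place of 3-methyl-1H-1,2,4-triazol-5-yl on an aromatic carbon. Among the measured compounds shown here, no measured step exchanges one five-membered ring for another, so the only guidance is no change at the digits printed from compound 1 to compound 2 (within the scatter), a change on the same ring that produced nothing beyond the scatter. On that basis the step to compound 3 is expected to be no change at the digits printed from compound 2 to compound 3 (within the scatter), no change beyond the scatter. Compound 3 is estimated at 0%, with a range from 0% to 15%.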

Compound 3, largest response reached (reported as maximal response), in percent of the reference or control that the assay uses: 104%
Compound 3: the middle estimate sits 104 percentage points below what was measured, outside the stated range (above it).
By their numbers in this assay, from the lowest: compounds 1 and 2 (each within the scatter of the next); then compound 3.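

Putting 1-methyl-1H-imidazol-2-yl in place of 3-methyl-1H-1,2,4-triazol-5-yl on this aromatic carbon gives a number 104 percentage points higher from compound 2 to compound 3 (beyond the scatter) in this assay, so the azole at this position can take the read-out from its floor to a full response, which the methyl-for-hydrogen change between compound 1 and compound 2 gave no sign of. The two groups have the same count of heavy atoms and of hydrogen-bond acceptors, so the step goes with a different set of ring atoms and the loss of the hydrogen-bond donor, not with a difference in those counts. Nothing available explains why this exchange has so large an effect.

Among these compounds, the single exchange does not separate the ring atoms from the placing of the methyl. It also leaves open whether an imidazole without its methyl, a pyrazole or a plain phenyl at this position would keep the response of compound 3.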